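Ring swap on the chain carbon of the core

The source may report more compounds than this note shows. Statements on the series, on what has been measured and on what is new or still open speak of the compounds shown alone.

Three compounds of the shared core have numbers in a physicochemical assay for lipophilicity, at pH 7.4; a higher number here means a more lipophilic compound, a lower number a more polar compound. Compound 1 `CNC(=O)c1cc(C(=O)NC2CC2)cn(Cc2nccc3[nH]ccc23)c1=O` gives 1.7 and stands lowest of the three; compound 3 `CNC(=O)c1cc(C(=O)NCCO)cn(Cc2ccccc2)c1=O` gives 1.9, within the scatter of compound 1, while compound 2 `CNC(=O)c1cc(C(=O)NC2CCC2)cn(Cc2cccc(NC)c2)c1=O` gives 3.6, the furthest from compound 1 and beyond the scatter. Going by the values given here, no step between two measured compounds that differ in one place is available.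

Compound 4 `CNC(=O)c1cc(C(=O)NC2CC2)cn(CC2CCOCC2)c1=O` differs from compound 1 as follows: a group of 6 heavy atoms (5 carbon, 1 oxygen; one six-membered non-aromatic ring with 1 hetero atom) in place of a group of 9 heavy atoms (7 carbon, 2 nitrogen; one five-membered aromatic ring with 1 hetero atom, one six-membered aromatic ring with 1 hetero atom), on a saturated chain carbon bound to an aromatic nitrogen. Among the compounds with values here, with no matched step to lean on, a small step upward in this assay is expected, of about a number 0.20 log units higher from compound 1 to compound 4 (within the scatter), and a result within the scatter of compound 1 would not surprise. Compound 4 is therefore estimated at 1.9, in the range 1.3 to 2.5.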

Compound 4, distribution coefficient: 1.5
The estimate for compound 4 lay 0.40 log units above the measured number; the measured number falls inside the stated range.
By their numbers in this assay, from the lowest: compounds 4, 1 and 3 (each within the scatter of the next, the first and the last beyond it); then compound 2.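

In this assay, going by these compounds alone, the first matched step, oxan-4-yl on a saturated chain carbon bound to an aromatic nitrogen gives a number 0.20 log units lower from compound 1 to compound 4 (within the scatter). At this position, therefore, a group with two aromatic rings and one hydrogen-bond donor can give way to one six-membered non-aromatic ring with no hydrogen-bond donor, with the change staying within the scatter. Nothing available explains this outcome.

Going by these compounds, whether an amine or a carboxylic acid on this chain carbon would also stay within the scatter of compound 1 remains open. Also open, on these data alone, is whether the same swap gives a similar step with the other amide groups seen in compound 2 and compound 3.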